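A few compounds are considered here, and "the series" means these few. Any claim that something is new, unique, unknown or untested is made for them only; others in the source may bear on it.

Working notes on the series in a toxicity assay on the whole organism (J774 cells) for cytotoxicity, with Mus musculus as the target, read by MTT assay, with a stated time of 24 h, tested at 30 uM; on this read-out lower numbers stand for a stronger effect and higher numbers for a weaker effect at the one concentration tested. Three compounds carry numbers. For the measured compounds named here, compound 1 `CCCCCCCCCO[C@@H]1[C@@H](N)[C@@H](OCC(O)CNCCCO)O[C@H](CN)[C@H]1OCCCCCCCCC` gives 13.7% and compound 3 `CCCCCCCCCO[C@@H]1[C@@H](N)[C@@H](OCC(O)CNCCCN)O[C@H](CN)[C@H]1OCCCCCCCCC` gives 71.6%; the one step between them that changes a single place, a number 57.9 percentage points higher from compound 1 to compound 3 (beyond the scatter), is the only such step measured. Compound 2 `NC[C@H]1O[C@H](O[C@H]2[C@H](O)[C@@H](O)[C@H](N)C[C@@H]2N)[C@H](N)[C@@H](OCCCc2ccc3ccccc3c2)[C@@H]1OCCCc1ccc2ccccc2c1` gives 66.9%, which is the second highest of the three numbers: its gap to compound 3 lies within the scatter, while its gap to compound 1 lies beyond it.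

Compound 4 `C=CCO[C@H]1O[C@H](CN)[C@@H](OCCCc2ccc3ccccc3c2)[C@H](OCCCc2ccc3ccccc3c2)[C@H]1N` is not yet measured. It differs from compound 2 as follows: allyl in place of 4,6-diamino-2,3-dihydroxycyclohexyl on an oxygen on a saturated carbon. Going by the values given here, no measured step touches this place; the one known step concerns an amino in place of a hydroxy on a chain carbon and does not bear on an exchange of a 4,6-diamino-2,3-dihydroxycyclohexyl for an allyl on an oxygen. Compounds 1 and 3, which also lack that cyclohexyl group, sit far apart from each other, so they give no direction either. The expectation for compound 4 is therefore a step of a number 6.9 percentage points lower from compound 2 to compound 4 (within the scatter) from compound 2, that is, none beyond the scatter, with a wide range. For compound 4 the estimate is 60%, expected between 30% and 85%.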

Compound 4, a percentage reported as activity, at one concentration (the size of the read-out at that concentration, not a potency): 7%
Estimate against measurement, compound 4: 53 percentage points above; the measured number lies below the stated range.
By their numbers in this assay, from the lowest: compounds 4 and 1 (each within the scatter of the next); then compounds 2 and 3 (each within the scatter of the next).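

In this assay, for the compounds shown here, the exchange of 4,6-diamino-2,3-dihydroxycyclohexyl for allyl on an oxygen on a saturated carbon gives the first reading at this place, and the step of a number 59.9 percentage points lower from compound 2 to compound 4 (beyond the scatter) is large, with a stronger effect at the one concentration tested. The group on this oxygen therefore has a large bearing on the read-out in this series, which the earlier step, confined to an amino in place of a hydroxy on a chain carbon, could not show. No measurement shown here accounts for the size of this step.

A single exchange that removes a ring with its amino and hydroxy groups and introduces a double bond cannot say which of these parts carries the step, and a propyl group, a plain cyclohexyl or an aminoethyl chain on the same oxygen would begin to separate them. As far as these compounds go, it also remains open whether the effect of an amino in place of a hydroxy, seen as a number 57.9 percentage points higher from compound 1 to compound 3 (beyond the scatter) on another chain, would appear on compound 4 as well.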